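Bromo to trifluoromethyl on the shared core

This account rests on a few compounds, and the source may have more. Where it says the series, first, only, none or still open, it means among the compounds named here.

Measured so far:
compound 1 `O=[N+]([O-])c1cccc(CNc2cc(Br)cc3[nH]ncc23)c1` — in an assay for inhibition of Tryptophan 2,3-dioxygenase (Homo sapiens), with stated times of 10 min and 60 min, tested at 100 uM (a lower number here means a weaker effect, a higher number a stronger effect of the compound at the concentration tested), compound 1 gives 97%
compound 2 `O=[N+]([O-])c1cccc(CNc2cc(C(F)(F)F)cc3[nH]ncc23)c1` — in this assay compound 2 gives 82%
compound 3 `O=[N+]([O-])c1ccc(CNc2cc(Br)cc3[nH]ncc23)cc1` — in this assay compound 3 gives 93%

Compounds 1 and 2 share one core; compound 3 carries the same atoms joined differently, and the difference between the two cores is not broken down here. Within the first core the one change is trifluoromethyl in place of bromo on an aromatic carbon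
which made a step of a number 15 percentage points lower from compound 1 to compound 2 (beyond the scatter). Compound 3 and compound 1 sit within the usual scatter of each other; compound 2 sits below compound 3, beyond the scatter.

Compound 4 `O=[N+]([O-])c1ccc(CNc2cc(C(F)(F)F)cc3[nH]ncc23)cc1` has not yet been measured in this assay. It differs from compound 3 by trifluoromethyl in place of bromo on an aromatic carbon
the same change, at the same place, as between compound 1 and compound 2. Because the earlier step was a number 15 percentage points lower from compound 1 to compound 2 (beyond the scatter), a step of about a number 15 percentage points lower from compound 3 to compound 4 (beyond the scatter) is expected from compound 3 to compound 4, with wide uncertainty as it rests on a single pair. Compound 4 is therefore estimated at 78%, between 65% and 90%.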

Compound 4, a percentage reported as inhibition, at one concentration (the size of the read-out at that concentration, not a potency): 64%
Compound 4: middle estimate off by 14 percentage points, on the high side, outside the stated range (below it).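

In this assay, trifluoromethyl in place of bromo again lowers the read-out, with a number 29 percentage points lower from compound 3 to compound 4 (beyond the scatter), so the change points the same way on both cores and the two step sizes cannot be told apart: the same change on two cores in this assay, a number 15 percentage points lower (beyond the scatter) from compound 1 to compound 2 and a number 29 percentage points lower (beyond the scatter) from compound 3 to compound 4, 14 percentage points apart, within the scatter of two such steps

What carries over between these two cores is the direction of the step, and the larger figure on the second core does not establish a real difference between the cores. Two pairs do not show that the step would hold on any further core, and a percentage at one concentration gives no measure of how far potency shifts.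

Open, on these data alone, is whether the fall is particular to trifluoromethyl or would also follow other groups at this place, such as chloro, methyl or a nitrile. Also open, as far as these compounds go, is whether the step persists when the nitro group gives way to an amine or a carboxylic acid.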